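This account rests on a few compounds, and the source may have more. Where it says the series, first, only, none or still open, it means among the compounds named here.

Working notes on the series

The shared core appears in compound 1 `COc1ccc(/C=C2\S/C(=N\c3ccc(F)cc3)N(C)C2=O)cc1`, compound 2 `COc1ccc(/C=C2\S/C(=N\c3ccc(OC)cc3)N(C)C2=O)cc1` and compound 3 `C=CC/N=C1\S/C(=C\c2ccc(OC)cc2)C(=O)N1C`; compound 4 `COc1ccc(/C=C2\S/C(=N\c3ccc(C)c(Cl)c3)N(C)C2=O)cc1` is the member still to be measured. In an ADME assay on TERT-RPE1 cells (Homo sapiens) for cytotoxicity, read by MTT assay, with a stated time of 72 h (a higher number here means a weaker inhibitor, a lower number a stronger inhibitor), compound 1 gives > 100000 nM, which is a limit of the assay and not a number. In this assay compound 2 gives > 100000 nM, again a limit. In this assay compound 3 gives > 100000 nM, also a limit. Compound 3 therefore stands at the same limit as the other two, and its position relative to them cannot be read because all three values sit at the limit of > 100000 nM in this assay, at which 3 of the 3 values shown sit.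

The change from compound 3 to compound 4 is 3-chloro-4-methylphenyl in place of allyl on a double-bonded nitrogen. The measured steps that bear on it run in the opposite sense, exchanging an aryl group on the double-bonded nitrogen for allyl: a step that the two limits leave unreadable from compound 1 to compound 3 and a step that the two limits leave unreadable from compound 2 to compound 3. Neither can be sized, nor can a step that the two limits leave unreadable from compound 1 to compound 2. No readable step exists on this nitrogen substituent, so no step beyond the scatter is expected from an aryl group returning there. The expected step is a step that the limit leaves unreadable from compound 3 to compound 4. Compound 4 is estimated at 150000 nM, with a range from 50000 nM to 500000 nM, and a report of a limit rather than a number is the more likely outcome.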

Compound 4, half-maximal inhibitory concentration: 23000 nM
For compound 4 the middle estimate is 6.5-fold (0.81 log units) above the measured one; measured number below the stated range.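

In this assay the double-bonded nitrogen now shows a readable change: 3-chloro-4-methylphenyl gives an at least 4.3-fold lower number from compound 3 to compound 4 (0.63 log units; beyond the scatter) in place of allyl, an at least 4.3-fold lower number from compound 2 to compound 4 (0.63 log units; beyond the scatter) in place of 4-methoxyphenyl and an at least 4.3-fold lower number from compound 1 to compound 4 (0.63 log units; beyond the scatter) in place of 4-fluorophenyl. Among these compounds, an aryl group on this nitrogen does not by itself give a measured number, as compound 1 and compound 2 also carry one and stay at a limit of the assay, so the series so far ties the change to 3-chloro-4-methylphenyl specifically and not to aryl groups in general. All three steps are lower bounds, and the steps among compound 1, compound 2 and compound 3 cannot be read because these compounds share one limit: the limit of > 100000 nM in this assay, at which 3 of the 4 values shown sit.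

As far as these compounds go, whether the step follows the chlorine or the methyl stays open, and a 3-chlorophenyl or a 4-methylphenyl group on this nitrogen would separate the two. Also open, from the compounds shown here alone, is what an amine or a carboxylic acid on that aromatic ring would do in this assay.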